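A Diaminoquinazoline Swap Tested Against Trypsin

The source may hold more compounds than are shown below. What is called first, only, known or untested is meant among the compounds shown, and "the series" means these compounds.

Compound 3 `Cc1cc(C(=O)Nc2ccc(-c3ccccc3S(N)(=O)=O)cc2)n(-c2ccc3onc(N)c3c2)n1` was measured in an assay on isolated protein for inhibition of Trypsin (Homo sapiens); on this read-out lower numbers stand for stronger inhibition and higher numbers for weaker inhibition. In this assay compound 3 gives > 1600 nM, which is a limit of the assay rather than a number. Its two neighbours stand at the same place. Compound 1 `Cc1cc(C(=O)Nc2ccc(-c3ccccc3S(N)(=O)=O)cc2)n(-c2cccc(C(N)=O)c2)n1` gives > 1600 nM in this assay, again a limit. Compound 2 `Cc1cc(C(=O)Nc2ccc(-c3ccccc3S(N)(=O)=O)cc2)n(-c2cccc(Cl)c2)n1` gives > 1600 nM in this assay, also a limit. This is summed up by the limit of > 1600 nM in this assay, at which 3 of the 3 values shown sit. The steps among the three, a step that the two limits leave unreadable from compound 1 to compound 2, a step that the two limits leave unreadable from compound 1 to compound 3 and a step that the two limits leave unreadable from compound 2 to compound 3, therefore cannot be read in size or direction.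

Compound 4 `Cc1cc(C(=O)Nc2ccc(-c3ccccc3S(N)(=O)=O)cc2)n(-c2ccc3nc(N)nc(N)c3c2)n1` has not yet been measured. The change from compound 3 is a group of 12 heavy atoms (8 carbon, 4 nitrogen; one six-membered aromatic ring of carbon only, one six-membered aromatic ring with 2 hetero atoms) in place of a group of 10 heavy atoms (7 carbon, 2 nitrogen, 1 oxygen; one five-membered aromatic ring with 2 hetero atoms, one six-membered aromatic ring of carbon only), on an aromatic nitrogen. Among the compounds with values here, none of the measured steps bears on this exchange: all three end at the limit and show neither how large a change in this part of the molecule can be nor which way it goes. For compound 4 the expected step of an at least 2.0-fold lower number from compound 3 to compound 4 (0.30 log units; that floor lies within the scatter) in this assay is therefore no more than a guess that the compound may move off the limit. Compound 4 is estimated at 800 nM, with a range from 100 nM to 3000 nM.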

Compound 4, inhibition constant: > 1600 nM
Compound 4: a limit, no number; the forecaster's own chance of this, stated with the estimate: 45%; middle value at least 2.0-fold (0.30 log units) away from the limit.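

In this assay compound 4 gives > 1600 nM, a limit of the assay and not a number. Its steps from compound 1, compound 2 and compound 3 therefore cannot be read in size or direction. All four compounds stand at the same place: the limit of > 1600 nM in this assay, at which 4 of the 4 values shown sit.

The compounds shown leave open whether any group on this aromatic nitrogen can bring a value off the limit.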